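Adding a Second Chloro to the Core of Compound 2

The compounds below may be only part of what the source reports. "The series", "measured", "known", "first", "only" and "open" are said of these compounds alone.

Compound 1 `ClCc1ccccc1Cn1cnc2c(Cl)nc(Cl)nc21` reaches only the limit of the assay, giving > 100000 nM in a functional assay on T47D cells (Homo sapiens) for cytotoxicity, read by sulforhodamine B assay, with a stated time of 48 h; a lower number here means that less compound is tolerated, a higher number that more compound is tolerated (the limit of > 100000 nM in this assay, at which 1 of the 2 values shown sits). Compound 2 `ClCc1ccccc1Cn1cnc2ncnc(Cl)c21` gives 4260 nM in this assay, the single numerical value among the compounds shown. Compound 3 `ClCc1ccccc1Cn1cnc2nc(Cl)nc(Cl)c21` differs from compound 2 by chloro in place of hydrogen on an aromatic carbon. Going by the values given here, no measured step shows what this change does, so the expected step from compound 2 to compound 3 in this assay is a modest one, with compound 3 expected to be tolerated somewhat more, a 1.9-fold higher number from compound 2 to compound 3 (0.27 log units; within the scatter). Compound 3 is therefore estimated at 8000 nM, within a range from 1500 nM to 50000 nM.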

Compound 3, concentration lethal to 50% of the cells: > 100000 nM
Compound 3: a limit, no number (the forecaster's own chance of this, stated with the estimate: 20%); at least 12-fold (1.09 log units) between middle value and limit.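

Chloro in place of hydrogen on an aromatic carbon between two ring nitrogen atoms is the first change at this position with a measured outcome, and in this assay it gives an at least 23-fold higher number from compound 2 to compound 3 (1.37 log units; beyond the scatter) on the addition of one heavy atom. That single atom is enough to carry the reading out of the measured range. Compound 3 gives > 100000 nM as a limit of the assay and not a number, a place it shares with another compound shown: the limit of > 100000 nM in this assay, at which 2 of the 3 values shown sit.

On these data alone, how far the true value of compound 3 lies past that limit stays open. So does whether an amine or a methoxy group at this position would keep the reading within the measured range.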